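A few compounds are considered here, and "the series" means these few. Any claim that something is new, unique, unknown or untested is made for them only; others in the source may bear on it.

Compound 1 `CCNC(=O)C1=C(C)NC(=O)NC1c1cccs1` carries an ethylcarbamoyl group on a double-bonded ring carbon of a shared core bearing a thiophene ring. For the measured compounds named here, in an assay on membranes from CHO cells for displacement of a labelled ligand from adenosine receptor A1 (Homo sapiens), read by scintillation counting, with a stated time of 60 min, tested at 1 uM (a lower number here means less inhibition, a higher number more inhibition at the concentration tested (going by the name of the read-out)), compound 1 gives 1%, the lowest of the two numbers measured so far. Going by the values given here, the only measured neighbour is compound 2 `CC1=C(c2ncc(C)o2)C(c2cccs2)NC(=O)N1`, which in this assay gives 21%; the step of a number 20 percentage points higher from compound 1 to compound 2 (beyond the scatter) lies beyond the scatter and is modest in size, with 5-methyl-1,3-oxazol-2-yl in place of ethylcarbamoyl on a double-bonded ring carbon. Compound 3 `CC1=C(C(=O)OC2CCCC2)C(c2cccs2)NC(=O)N1` has not yet been measured. It differs from compound 1 by cyclopentyloxy in place of ethylamino on a carbonyl carbon. Among the compounds with values here, no measured step exchanges an amide for an ester at that carbonyl carbon, so only the step from compound 1 to compound 2 bears on it, showing that alterations at this side of the core can move the number modestly. For compound 3 a small upward step a number 11 percentage points higher from compound 1 to compound 3 (beyond the scatter) is therefore expected, of uncertain size. The estimate for compound 3 in this assay is 12%, within a range from -8% to 35%.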

Compound 3, a percentage reported as inhibition, at one concentration (the size of the read-out at that concentration, not a potency): 9%
Estimate against measurement, compound 3: 3 percentage points above, within the range that was stated.
By their numbers in this assay, from the lowest: compounds 1 and 3 (each within the scatter of the next); then compound 2.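

In this assay, replacing ethylamino with cyclopentyloxy on a carbonyl carbon gives a number 8 percentage points higher from compound 1 to compound 3 (within the scatter). The carbonyl stays in place while the ethylamino group and its hydrogen-bond donor give way to a larger group with a five-membered non-aromatic ring of carbon only, and this exchange does not separate the ester from the amide in this read-out. Replacing the whole ethylcarbamoyl group, by contrast, gives a number 20 percentage points higher from compound 1 to compound 2 (beyond the scatter), and nothing shown here explains either result.

Going by these compounds, it remains open whether an ethoxy group, a longer chain or a hydroxyl group giving the carboxylic acid on that carbonyl carbon would move the number beyond the scatter. On these data alone, each number comes from a single concentration, so potency is also open, as is the effect of replacing the thiophene ring with a phenyl ring.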